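Truncating the alkynyl chain of compound 1 to a terminal alkyne

The source may report more compounds than this note shows. Statements on the series, on what has been measured and on what is new or still open speak of the compounds shown alone.

Compound 1 `CCCCCCC#Cc1ccc(S(=O)(=O)Nc2cccc(-c3csc(NC(C)=O)n3)c2)cc1` carries an oct-1-yn-1-yl group on the shared core. In a functional assay on A-375 cells (Homo sapiens) for antiproliferative activity, read by trypan blue exclusion, with a stated time of 48 h, tested at 1 uM (a lower number here means a stronger effect, a higher number a weaker effect of the compound at the concentration tested), compound 1 gives 40.7%, the lowest of the two numbers in the set. Compound 3 `CC(=O)Nc1nc(-c2cccc(NS(=O)(=O)c3ccc(C#CC4CCCCC4)cc3)c2)cs1` differs only by cyclohexyl in place of hexyl on a triple-bonded carbon; compound 3 gives 52.3%, and the step is a number 11.6 percentage points higher from compound 1 to compound 3 (beyond the scatter). Compound 2 `CC(=O)Nc1nc(-c2cccc(NS(=O)(=O)c3ccc(Br)cc3)c2)cs1` lacks the alkynyl substituent altogether; for compound 2 the outcome in this assay is "not active" (no number reported), with no number reported.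

Compound 4 `C#Cc1ccc(S(=O)(=O)Nc2cccc(-c3csc(NC(C)=O)n3)c2)cc1` is the next step from compound 1: hydrogen in place of hexyl on a triple-bonded carbon. For the measured compounds named here, the one measured step that bears on it, a number 11.6 percentage points higher from compound 1 to compound 3 (beyond the scatter), shows that altering the end of the chain already costs a modest amount, and compound 2, with no chain at all, gave no measurable activity. Both observations point the same way: with the hexyl chain removed, a weaker effect than for compound 1 is expected, and a step larger than that to compound 3. The expected step for compound 4 is a number 29.3 percentage points higher from compound 1 to compound 4 (beyond the scatter). Compound 4 is estimated at 70%, with a range from 50% to 95%, and a report of no activity, as for compound 2, remains a real possibility.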

Compound 4, a percentage reported as activity, at one concentration (the size of the read-out at that concentration, not a potency): 59.2%
The estimate for compound 4 lay 10.8 percentage points above the measured number; the measured number falls inside the stated range.
By their numbers in this assay, from the lowest: compound 1; then compounds 3 and 4 (each within the scatter of the next).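

Working notes on the alkyne position. In this assay compound 4 gives 59.2% as a number on the scale, whereas compound 2, which has no alkynyl substituent, is recorded as "not active" (no number reported) in the same test, so the ethynyl group alone is enough to give a reported number. Replacing hexyl with hydrogen on the triple-bonded carbon gives a number 18.5 percentage points higher from compound 1 to compound 4 (beyond the scatter) and thus a weaker effect, while replacing cyclohexyl with hydrogen gives a number 6.9 percentage points higher from compound 3 to compound 4 (within the scatter) and separates nothing, which leaves the oct-1-yn-1-yl group of compound 1 as the only alkyne here that stands apart from the other two. Nothing available accounts for this difference between the open chain and the other two end groups.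

On these data alone, whether a chain longer than hexyl, or a shorter one such as propyl, would take the number lower than in compound 1 remains open, as does the outcome for a chain ending in an amine or a hydroxyl group. All these readings come from a single concentration, so the potency of the alkynes in the series also remains undefined.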